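The source may report more compounds than this note shows. Statements on the series, on what has been measured and on what is new or still open speak of the compounds shown alone.

Measured so far:
compound 1, `O=C(O)C1=Cc2ccccc2OC1(OCc1cc(-c2ccc(F)cc2F)no1)C(F)(F)F`: > 150000 nM
compound 2, `CCOC(=O)C1=Cc2ccccc2OC1(OCc1cc(-c2cccc(C(F)(F)F)c2)no1)C(F)(F)F`: 48600 nM

Among the compounds with values here, in a functional assay on A549 cells (Homo sapiens) for inhibition, read by MTT assay, with a stated time of 24 h (on this read-out higher numbers stand for weaker inhibition and lower numbers for stronger inhibition), compound 2 gives 48600 nM, the only numeric value in the set. For compound 1 the result is a limit of the assay, (the limit of > 150000 nM in this assay, at which 1 of the 2 values shown sits). Compound 3, `O=C(O)C1=Cc2ccccc2OC1(OCc1cc(-c2cccc(C(F)(F)F)c2)no1)C(F)(F)F`, differs from compound 2 by hydrogen in place of ethyl on an oxygen next to a carbonyl group, ethoxycarbonyl to carboxy. Within the data shown here, no measured pair isolates this change; the other carboxy compound, compound 1, reaches only a limit, (the limit of > 150000 nM in this assay, at which 1 of the 2 values shown sits). A loss beyond the scatter is expected, a 2.5-fold higher number from compound 2 to compound 3 (0.39 log units; beyond the scatter). Compound 3 is estimated at 120000 nM, within 40000 nM to 300000 nM.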

Compound 3, half-maximal inhibitory concentration: > 150000 nM
Compound 3: no number, only a limit; the forecaster's own chance of this, stated with the estimate: 50%; at least 1.2-fold (0.09 log units) between middle value and limit.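

In this assay, within the data shown here, ethoxycarbonyl to carboxy gives an at least 3.0-fold higher number from compound 2 to compound 3 (0.48 log units; beyond the scatter), the first measured pair to isolate this change, and the direction is a loss beyond the scatter. The result for compound 3 is a limit of the assay, not a number: the limit of > 150000 nM in this assay, at which 2 of the 3 values shown sit. The step between the two carboxy compounds cannot be read, so 3-(trifluoromethyl)phenyl in place of 2,4-difluorophenyl has no size here.

Open, from the compounds shown here alone, is how a methyl group, a longer chain or an amide at this carbonyl would read. Also open, going by these compounds, is how 2,4-difluorophenyl reads with the ethyl group kept.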